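Compound 4 lengthens the methoxycarbonyl chain of compound 1

The source may hold more compounds than are shown below. What is called first, only, known or untested is meant among the compounds shown, and "the series" means these compounds.

Measured compounds in an ADME assay on MDCK cells (Canis lupus familiaris) for cytotoxicity, read by microscopy, with a stated time of 72 h; a lower number here means that less compound is tolerated, a higher number that more compound is tolerated:
compound 1 `COC(=O)C[C@H](NC(=O)OC(C)(C)C)C(=O)N(Cc1ccc(F)cc1)C1(C(=O)NCc2ccccc2)CCN(Cc2ccccc2)CC1` — > 100000 nM
compound 2 `CCC(C)N(C(=O)[C@H](CC(=O)OC)NC(=O)OC(C)(C)C)C1(C(=O)NCc2ccccc2)CCN(Cc2ccccc2)CC1` — 84000 nM
compound 3 `COC(=O)C[C@H](NC(=O)OC(C)(C)C)C(=O)N(Cc1ccc(Cl)cc1)C1(C(=O)NCc2ccccc2)CCN(Cc2ccccc2)CC1` — 100000 nM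

The value for compound 1 in this assay is a limit, not a measured number. Compound 2 and compound 3 report numbers that sit near that limit, and the steps between the three are small: an at least 1.1-fold lower number from compound 1 to compound 2 (0.07 log units; that floor lies within the scatter); a 1.2-fold higher number from compound 2 to compound 3 (0.08 log units; within the scatter); a number no higher from compound 1 to compound 3 (the limit leaves the size open). The set includes (the limit of > 100000 nM in this assay, at which 1 of the 3 values shown sits). Compound 1 therefore stands at the top of what the assay can report, and none of the three compounds can be ordered against the others.

Compound 4 `COC(=O)CC[C@H](NC(=O)OC(C)(C)C)C(=O)N(Cc1ccc(F)cc1)C1(C(=O)NCc2ccccc2)CCN(Cc2ccccc2)CC1` differs from compound 1 in one place: (methoxycarbonyl)methyl in place of methoxycarbonyl on a saturated chain carbon, two bonds along the chain from an amide-type nitrogen and a carbonyl carbon. Going by the values given here, none of the measured steps touches this chain; all of them concern the amide-type nitrogen or the aromatic carbon, and all lie within the scatter. Among the compounds with values here, no measured step bears on the change to compound 4, so no step beyond the scatter is expected in this assay, and a limit is again likely. Compound 4 is expected at 100000 nM, with a range from 50000 nM to 200000 nM. The expected step is a number no higher from compound 1 to compound 4 (the limit leaves the size open), within the scatter.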

Compound 4, minimum cytotoxic concentration: > 100000 nM
Compound 4: no number, only a limit; the forecaster's own chance of this, stated with the estimate: 60%; the middle value sits exactly at the limit.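

In this assay compound 4 gives > 100000 nM, which is a limit and not a number. Compound 1 gives > 100000 nM, also a limit, so no step can be read between compound 1 and compound 4. The compounds shown leave open whether (methoxycarbonyl)methyl in place of methoxycarbonyl changes how much compound is tolerated at all.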